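Clearance of two sulfonamide neighbours in human liver microsomes

A few compounds are considered here, and "the series" means these few. Any claim that something is new, unique, unknown or untested is made for them only; others in the source may bear on it.

Measured so far in an in vitro ADME assay on microsomes from liver (Homo sapiens) for metabolic stability, read by LC-MS, tested at 1 uM; on this read-out higher numbers stand for fast clearance and lower numbers for slow clearance:
- Compound 1 (`O=C(O)COc1ccc(Cl)cc1C#Cc1ccc(CO)cc1F`): < 10 mL.min-1.g-1 (a limit of the assay, not a number)
- Compound 2 (`COCCN(C)S(=O)(=O)c1ccc(C)c(C#Cc2cc(Cl)ccc2OCC(=O)O)c1`): 32 mL.min-1.g-1 (a measured number)

Going by the values given here, compound 2 holds the only true number in this small set, as the single other reading is a limit. Among the compounds with values here, no pair of measured compounds differs in one place, so the data offer no measured step to scale from.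

The next compound is compound 3 (`Cc1ccc(S(=O)(=O)NC(C)C)cc1C#Cc1cc(Cl)ccc1OCC(=O)O`). Within the data shown here, it keeps the core of compound 2 and carries isopropylamino in place of (2-methoxyethyl)(methyl)amino on a sulfonyl sulfur as its only change.

The expectation for compound 3 in this assay starts from compound 2 at 32 mL.min-1.g-1 and allows only a modest move. The expected step of a 1.5-fold lower number from compound 2 to compound 3 (0.16 log units; within the scatter) is small, leaning toward slower clearance, and is not expected to go beyond the usual scatter of repeat measurements. For compound 3 the estimated clearance is 22 mL.min-1.g-1 as the central figure, with an expected range from 11 mL.min-1.g-1 to 45 mL.min-1.g-1 around it.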

Compound 3, intrinsic clearance in microsomes: < 10 mL.min-1.g-1
Compound 3: only a limit was reported (the forecaster's own chance of this, stated with the estimate: 15%); middle value at least 2.2-fold (0.34 log units) away from the limit.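

Working notes on the sulfonamide position: this is the first change in one place in the set, and it shows that the group on the sulfonyl sulfur matters for clearance. In this assay, isopropylamino in place of (2-methoxyethyl)(methyl)amino gives an at least 3.2-fold lower number from compound 2 to compound 3 (0.50 log units; beyond the scatter). The reading for compound 3 is a limit of the assay, not a number. The step is therefore a minimum, and its full size stays unknown because the read-out ends at this limit: the limit of < 10 mL.min-1.g-1 in this assay, at which 2 of the 3 values shown sit.

The compounds shown do not separate the loss of the 2-methoxyethyl chain from the gain of the hydrogen on the sulfonamide nitrogen, as both arrive in the same single change. Dimethylamino on the same sulfonyl sulfur would pull these two apart, keeping a fully substituted nitrogen while removing the ether oxygen, and a result there that sat clear of the limit would give a true number to scale further changes at this position from.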